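Adding a Second Methyl to Compound 2

The compounds below may be only part of what the source reports. "The series", "measured", "known", "first", "only" and "open" are said of these compounds alone.

In a functional assay on B16-F0 cells (Mus musculus) for inhibition, read by CCK-8 assay, with a stated time of 48 h (on this read-out lower numbers stand for stronger inhibition and higher numbers for weaker inhibition), compound 1 `COc1cc(-c2ccnc3cc(-c4ccc(Cl)cc4)nn23)cc(OC)c1OC` gives 4090 nM, while compound 2 `COc1cc(-c2ccnc3cc(-c4ccc(C)cc4)nn23)cc(OC)c1OC` gives 21 nM, the lower of the two numbers. Among the measured compounds shown here, the only measured step, a 190-fold lower number from compound 1 to compound 2 (2.29 log units; beyond the scatter), is large and beyond the scatter, and it puts methyl in place of chloro on an aromatic carbon. Compound 3 `COc1cc(-c2ccnc3cc(-c4ccc(C)c(C)c4)nn23)cc(OC)c1OC` keeps that methyl and gains another: methyl in place of hydrogen on an aromatic carbon, which turns 4-methylphenyl into 3,4-dimethylphenyl. For the measured compounds named here, the single measured step shows that one exchange on this ring can move the number greatly, but no measured step adds a group here, so its direction does not carry over. A moderate move toward weaker inhibition is expected, and the estimated step is a 2.9-fold higher number from compound 2 to compound 3 (0.46 log units; beyond the scatter). For compound 3 the estimated value is 60 nM, within a range from 12 nM to 400 nM.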

Compound 3, half-maximal inhibitory concentration: 391 nM
Compound 3: the middle estimate sits 6.5-fold (0.81 log units) below what was measured; the range from low to high includes it.
By their numbers in this assay, from the lowest: compound 2; then compound 3; then compound 1.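

In this assay the new methyl sits ortho to a methyl group, and the step of a 19-fold higher number from compound 2 to compound 3 (1.27 log units; beyond the scatter) shows that this ring carbon does not accept a methyl without a large loss. Adding a single methyl undoes much of the gain that the 4-methylphenyl group gave over the 4-chlorophenyl group, although the step of a 10-fold lower number from compound 1 to compound 3 (1.02 log units; beyond the scatter) still leaves 3,4-dimethylphenyl on the stronger side of 4-chlorophenyl. No measurement is available that explains why this methyl has such a large effect.

The compounds shown leave open whether the loss belongs to methyl alone or to any group at this place, a question that fluoro, hydroxyl or methoxy there could address. They also leave open how a longer chain, such as ethyl, would read in place of the methyl of compound 2.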